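From Dichlorobenzyl to Methoxybenzyl on the Amine Arm

The compounds below may be only part of what the source reports. "The series", "measured", "known", "first", "only" and "open" are said of these compounds alone.

Compound 1 `O=S(=O)(NCCCNCc1ccc(Cl)c(Cl)c1)c1cc(C(F)(F)F)cc(C(F)(F)F)c1` is tested in a functional assay on BXPC-3 cells (Homo sapiens) for inhibition, read by MTT assay, with a stated time of 72 h (a lower number here means a stronger inhibitor of growth, a higher number a weaker inhibitor of growth), where compound 1 gives 1400 nM. Among the three measured compounds this is the second highest number: compound 3 `O=S(=O)(NCCCNCC1COc2ccccc2O1)c1cc(C(F)(F)F)cc(C(F)(F)F)c1` gives 1200 nM, and the step of a 1.2-fold lower number from compound 1 to compound 3 (0.07 log units; within the scatter) stays within the scatter, while compound 2 `COc1ccc(CNCCCNS(=O)(=O)c2cc(C(F)(F)F)cc(C(F)(F)F)c2)cc1OC` gives 13000 nM, with the step of a 9.3-fold higher number from compound 1 to compound 2 (0.97 log units; beyond the scatter) lying beyond it. Compound 4 `COc1cccc(CNCCCNS(=O)(=O)c2cc(C(F)(F)F)cc(C(F)(F)F)c2)c1` differs from compound 1 by 3-methoxyphenyl in place of 3,4-dichlorophenyl on a saturated chain carbon bound to an amine nitrogen. The step that bears on this is the one placing 3,4-dimethoxyphenyl in place of 3,4-dichlorophenyl, which weakened growth inhibition by a 9.3-fold higher number from compound 1 to compound 2 (0.97 log units; beyond the scatter). Because that step a 9.3-fold higher number from compound 1 to compound 2 (0.97 log units; beyond the scatter) was modest and only a 3-methoxyphenyl enters here, compound 4 is expected to lose somewhat less, a step of a 3.6-fold higher number from compound 1 to compound 4 (0.55 log units; beyond the scatter). The estimate for compound 4 is 5000 nM, ranging from 2000 nM to 14000 nM.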

Compound 4, concentration for 50% growth inhibition: 1700 nM
Beside the measured number, compound 4's estimate is 2.9-fold (0.47 log units) above it; the measured number lies below the stated range.
By their numbers in this assay, from the lowest: compounds 3, 1 and 4 (each within the scatter of the next); then compound 2.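

Placing 3-methoxyphenyl in place of 3,4-dichlorophenyl on this saturated chain carbon leaves the number within the scatter (a 1.2-fold higher number from compound 1 to compound 4 (0.08 log units; within the scatter)), so a methoxy group on this ring does not always bring the loss seen with compound 2. Hydrogen in place of methoxy on an aromatic carbon gives a modest gain (a 7.6-fold lower number from compound 2 to compound 4 (0.88 log units; beyond the scatter)). The 2,3-dihydro-1,4-benzodioxin-2-yl group and 3-methoxyphenyl also stay within the scatter of each other (a 1.4-fold higher number from compound 3 to compound 4 (0.15 log units; within the scatter)).

Going by these compounds, whether 4-methoxyphenyl or 3-chlorophenyl would match compound 4 remains open. No supporting data are available to explain these results.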